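Replacing a pyrimidine ether with a quinazoline ether

The source may report more compounds than this note shows. Statements on the series, on what has been measured and on what is new or still open speak of the compounds shown alone.

Compound 1 `CCOC(=O)c1c(C)noc1OCC(=O)[C@H](CC(=O)O)NC(=O)[C@@H](NC(=O)COc1cccc2ccccc12)C(C)C` in a functional assay on Jurkat cells (Homo sapiens) for inhibition (on this read-out higher numbers stand for weaker inhibition and lower numbers for stronger inhibition), gives only a limit, > 200000 nM.
Compound 2 `CC(C)[C@H](NC(=O)COc1cccc2ccccc12)C(=O)N[C@@H](CC(=O)O)C(=O)CSc1nc(-c2ccccc2)no1` in this assay gives 102000 nM.
Compound 3 `CC(C)[C@H](NC(=O)COc1cccc2ccccc12)C(=O)N[C@@H](CC(=O)O)C(=O)COc1nccc(C(F)(F)F)n1` in this assay gives only a limit, > 200000 nM.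

Compound 3 thus has no number of its own; its value is a limit, the one described by the limit of > 200000 nM in this assay, at which 2 of the 3 values shown sit, where two of the three values sit. Compound 4 `CC(C)[C@H](NC(=O)COc1cccc2ccccc12)C(=O)N[C@@H](CC(=O)O)C(=O)COc1ncnc2ccccc12` differs from compound 3 in one place: quinazolin-4-yl in place of 4-(trifluoromethyl)pyrimidin-2-yl on an oxygen on a saturated carbon. The measured steps that change this same position are an at least 1.9-fold higher number from compound 2 to compound 3 (0.29 log units; that floor lies within the scatter), which rests on a limit and a number, and a step that the two limits leave unreadable from compound 1 to compound 3, which two limits leave unreadable. Going by the values given here, neither step shows a change beyond the usual scatter, and no measured step tells how a quinazolin-4-yl group behaves here. The expectation for compound 4 is therefore a value near that of compound 3, with a good chance that this assay again reports only a limit; the step of an at least 1.3-fold lower number from compound 3 to compound 4 (0.12 log units; that floor lies within the scatter) is estimated as no step beyond the scatter. Compound 4 is estimated at 150000 nM, between 40000 nM and 400000 nM.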

Compound 4, half-maximal inhibitory concentration: > 200000 nM
Compound 4: a limit, no number; the forecaster's own chance of this, stated with the estimate: 45%; middle value at least 1.3-fold (0.12 log units) from the limit.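

In this assay compound 4 gives > 200000 nM, which is a limit and not a number. Going by these compounds alone, the one readable step is an at least 1.9-fold higher number from compound 2 to compound 4 (0.29 log units; that floor lies within the scatter), so even this change of both the ring and its linking atom cannot be told apart from repeat-measurement noise, and the steps between two limits cannot be read at all. Putting quinazolin-4-yl on this oxygen, which brings in a six-membered aromatic ring of carbon only, therefore adds a second ring type that gives no number, and the series stays at the edge of the read-out: the limit of > 200000 nM in this assay, at which 3 of the 4 values shown sit.

Open, as far as these compounds go, is how far compounds 1, 3 and 4 lie past that limit, so no order among them can be given. Also open, from the compounds shown here alone, is whether a (quinazolin-4-yl)sulfanyl group or a simple amine on this saturated carbon would give a number.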